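The source may hold more compounds than are shown below. What is called first, only, known or untested is meant among the compounds shown, and "the series" means these compounds.

Compound 1 `Cc1cc2nn(-c3ccccc3)c(N)c2c(=O)[nH]1` gives -1% in an assay on isolated protein for inhibition of serine/threonine-protein kinase D2 (Homo sapiens), read by mobility shift assay, tested at 30 uM (on this read-out lower numbers stand for less inhibition and higher numbers for more inhibition at the one concentration tested (going by the name of the read-out)), the lower of the two numbers shown; compound 2 `COc1ccccc1-c1cc2nn(-c3ccccc3)c(N)c2c(=O)[nH]1` gives 20%, and the step of a number 21 percentage points higher from compound 1 to compound 2 (beyond the scatter) lies beyond the scatter. Compound 3 `Cc1[nH]c(=O)c2c(N)n(-c3ccccc3)nc2c1-c1ccccc1` differs from compound 1 by phenyl in place of hydrogen on an aromatic carbon. Among the compounds with values here, the only step measured, from compound 1 to compound 2, added an aryl group at a different carbon and raised inhibition modestly, so a comparable or smaller rise is expected here, with no step in the same place to confirm it. For compound 3 an inhibition of 8% is estimated, in a range from -10% to 30%, a step of a number 9 percentage points higher from compound 1 to compound 3 (within the scatter).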

Compound 3, a percentage reported as inhibition, at one concentration (the size of the read-out at that concentration, not a potency): -3%
Beside the measured number, compound 3's estimate is 11 percentage points above it; measured number inside the range.
By their numbers in this assay, from the lowest: compounds 3 and 1 (each within the scatter of the next); then compound 2.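

In this assay, phenyl in place of hydrogen on the aromatic carbon ortho to a methyl group gives a number 2 percentage points lower from compound 1 to compound 3 (within the scatter). An added aromatic ring at this position therefore yields no step beyond the scatter, whereas the 2-methoxyphenyl at the other carbon gave a number 21 percentage points higher from compound 1 to compound 2 (beyond the scatter). No available evidence bears on this result.

Open, on these data alone, is whether an amine, a carboxylic acid or a 2-methoxyphenyl at this carbon would give a different number. Also open, as far as these compounds go, is whether any group here would add to the step seen with 2-methoxyphenyl at the other carbon.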